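This account rests on a few compounds, and the source may have more. Where it says the series, first, only, none or still open, it means among the compounds named here.

Compound 1 `CCOC(=O)C1=C(O)/C(=C\c2cc(C)n(-c3ccc(F)cc3)c2C)N=C1C` gives 3.1 ug/mL
Compound 2 `CCOC(=O)C1=C(C)N/C(=C/c2cc(C)n(-c3ccc(F)cc3F)c2C)C1=O` gives 6.3 ug/mL
Compound 3 `CCOC(=O)C1=C(C)N/C(=C/c2cc(C)n(-c3cc(OC)c(OC)c(OO)c3)c2C)C1=O` gives 3.1 ug/mL

These numbers come from a physicochemical assay for solubility, read by nephelometry, in phosphate buffer, measured as kinetic solubility, at pH 6.5 (on this read-out higher numbers stand for higher solubility and lower numbers for lower solubility), and lie close together. Compound 2 stands highest of the three, while compound 1 and compound 3 each sit lower by a gap just beyond the usual scatter. Compound 4 `CCOC(=O)C1=C(C)N/C(=C/c2cc(C)n(-c3cccc(OC)c3)c2C)C1=O` has not been measured yet. Compared with compound 2, it has 3-methoxyphenyl in place of 2,4-difluorophenyl on an aromatic nitrogen. Among the compounds with values here, no measured pair differs in only one place, so no direct precedent exists. The narrow span from compound 3 (3.1 ug/mL) to compound 2 (6.3 ug/mL) suggests a modest outcome. A small downward step within the scatter is expected (a 1.3-fold lower number from compound 2 to compound 4 (0.10 log units; within the scatter)). In this assay the estimate for compound 4 is 5 ug/mL (expected range 2 ug/mL to 12 ug/mL).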

Compound 4, solubility: < 1.6 ug/mL
Compound 4 gave a limit, no number; the forecaster's own chance of this, stated with the estimate: 10%; middle value at least 3.1-fold (0.49 log units) from the limit.
By their numbers in this assay, from the lowest: compounds 1 and 3 (each within the scatter of the next); then compound 2. At a limit, below all of these: compound 4.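

In this assay, compound 4 reads < 1.6 ug/mL, which is a limit of the assay and not a number. Within the data shown here, putting 3-methoxyphenyl in place of 2,4-difluorophenyl on the aromatic nitrogen gives an at least 3.9-fold lower number from compound 2 to compound 4 (0.59 log units; beyond the scatter), the first step here that changes only one place. The group on this nitrogen therefore matters to the read-out, with this single change taking the value down to the assay's limit: the limit of < 1.6 ug/mL in this assay, at which 1 of the 4 values shown sits.

The compounds shown do not separate the effect of adding the methoxy group from that of losing the two fluorines. From the compounds shown here alone, how a phenyl carrying an amine or a carboxylic acid would read at this nitrogen remains open.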